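Ethyl in Place of Nitro on a Shared Phenol Core

The source may hold more compounds than are shown below. What is called first, only, known or untested is meant among the compounds shown, and "the series" means these compounds.

Compound 1 `Cc1ccnc(NC(c2ccc([N+](=O)[O-])cc2)c2ccc3cccnc3c2O)c1` gives 530 nM.
Compound 2 `Oc1cc2c(cc1C(c1ccc(F)cc1)N1CCCCC1)CCC2` gives only a limit, > 30000 nM.
Compound 3 `Oc1cc2c(cc1C(c1ccc(F)cc1)N1CCCCC1)CCCC2` gives only a limit, > 100000 nM.

These three compounds were tested in an assay for inhibition of protein disulfide-isomerase (Homo sapiens), with a stated time of 1 h; on this read-out lower numbers stand for stronger inhibition and higher numbers for weaker inhibition. For the measured compounds named here, compound 1 is the only one with a measured number, 530 nM, so it stands alone among the values shown. Compound 2 and compound 3 each reached a limit of this assay, marked by the limit of > 30000 nM in this assay, at which 1 of the 3 values shown sits, and (the limit of > 100000 nM in this assay, at which 1 of the 3 values shown sits), and no number is known for them. Going by the values given here, no two measured compounds differ in only one place, so no measured step exists to guide the next comparison.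

Compound 4 `CCc1ccc(C(Nc2cc(C)ccn2)c2ccc3cccnc3c2O)cc1` differs from compound 1 by a single change: ethyl in place of nitro on an aromatic carbon. Among the compounds with values here, with no measured step of this kind to lean on, a modest weakening is expected rather than a change far beyond the usual scatter. The step of a 2.3-fold higher number from compound 1 to compound 4 (0.35 log units; beyond the scatter) is therefore expected to be small. Compound 4 is estimated at 1200 nM, with a likely range from 300 nM to 5000 nM.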

Compound 4, half-maximal inhibitory concentration: 5390 nM
Compound 4: middle estimate off by 4.5-fold (0.65 log units), on the low side; the measured number lies above the stated range.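

This position is sensitive to what it carries: with the rest of the molecule unchanged, putting ethyl in place of nitro, para to a large group, gives a 10-fold higher number from compound 1 to compound 4 (1.01 log units; beyond the scatter) in this assay. The loss is not complete, as compound 4 still gives a measured number, 5390 nM, rather than a limit of the assay. Nothing shown here measures a property of either group that could explain the size of this step.

The compounds shown leave open how other groups at this position, such as a nitrile, an amine or a carboxylic acid, would compare with nitro and ethyl. A single pair also cannot tell whether a longer chain such as propyl would raise the number further, or whether the same change would matter as much on a different core.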